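Ester Variation on a Shared Core at Adenosine A2b

A few compounds are considered here, and "the series" means these few. Any claim that something is new, unique, unknown or untested is made for them only; others in the source may bear on it.

Measured compounds:
compound 1 `CC1=C(C(=O)OCc2ccccc2)C(c2ccco2)NC(=O)N1` – 887 nM
compound 2 `CC1=C(C(=O)OC(C)C)[C@@H](c2ccco2)NC(=S)N1` – 6.3 nM

Of the compounds shown here, two have been measured in an assay on membranes from HEK293 cells for displacement of a labelled ligand from adenosine receptor A2b (Homo sapiens), read by scintillation counting, with a stated time of 30 min; a lower number here means a stronger inhibitor, a higher number a weaker inhibitor. Compound 1 stands highest of the two numbers, giving 887 nM, while compound 2 gives 6.3 nM, a difference well beyond the scatter. Compound 2, however, differs from compound 1 in more than one place at once, so the two values alone do not show what any single change does.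

Compound 3 `CC1=C(C(=O)OCC2CCC2)C(c2ccco2)NC(=O)N1` keeps the core of compound 1 and changes only the ester group: cyclobutyl in place of phenyl on a saturated chain carbon bound to an oxygen next to a carbonyl group. Within the data shown here, no measured pair isolates this change. With the two values shown, the smaller ester of compound 2 going with the lower number is the only hint, and it is a weak one. A modest step downward is expected from compound 1 to compound 3, a 2.0-fold lower number from compound 1 to compound 3 (0.29 log units; within the scatter), of a size near the edge of the scatter. Compound 3 is expected to give about 450 nM, in a range from 120 nM to 1800 nM.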

Compound 3, inhibition constant: 561 nM
For compound 3 the middle estimate is 1.2-fold (0.10 log units) below the measured one, within the range that was stated.
By their numbers in this assay, from the lowest: compound 2; then compounds 3 and 1 (each within the scatter of the next).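

Among these compounds, compound 3 gives the first reading of a single change at this place: with cyclobutyl in place of phenyl on a saturated chain carbon bound to an oxygen next to a carbonyl group, this assay shows (a 1.6-fold lower number from compound 1 to compound 3 (0.20 log units; within the scatter)). The six-membered aromatic ring of carbon can therefore give way to a four-membered non-aromatic ring without a shift that stands out from the scatter, so an aromatic ring at this place is not required to keep the number in this range. Nothing at hand explains why the two esters read so alike.

Going by these compounds, whether an amine, a carboxylic acid or a longer chain at this place would move the number remains open. Also open, on these data alone, is which of the several differences in compound 2 goes with its 6.3 nM value.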